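The compounds below may be only part of what the source reports. "The series", "measured", "known", "first", "only" and "open" are said of these compounds alone.

Measured compounds:
compound 1 `O=C(CCl)Nn1c(S)nnc1COc1ccccc1C1=NOC(c2ccc(Cl)cc2Cl)C1`: 3.2 ug/mL
compound 2 `C=CCSc1nnc(COc2ccccc2C2=NOC(c3ccc(Cl)cc3Cl)C2)n1NC(C)=O`: "not determined" (no result reported)

The account follows the step from compound 2 to compound 3. In an ADME assay (MDM cells, Homo sapiens) for cytotoxicity, read by resazurin assay, with a stated time of 3 days (a lower number here means a stronger inhibitor, a higher number a weaker inhibitor), compound 1 gives 3.2 ug/mL. Compound 2 has no number in this assay, so it stands nowhere on the scale; only its structure is known. For the measured compounds named here, compound 3 `CC(=O)Nn1c(S)nnc1COc1ccccc1C1=NOC(c2ccc(Cl)cc2Cl)C1` differs from compound 2 by a single change, (hydrogen in place of allyl on a sulfur), and no measured pair shows what such a change does in this assay. Going by the values given here, compound 3 shares with compound 1 the free sulfur and the whole remaining core, differing only in the acyl group on the nitrogen, a pair for which no step is tabulated either. On that thin ground compound 3 is expected to land near compound 1 or somewhat weaker, with a wide range. The estimate for compound 3 in this assay is 10 ug/mL, from 3 ug/mL to 40 ug/mL.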

Compound 3, half-maximal inhibitory concentration: 1.3 ug/mL
Estimate against measurement, compound 3: 7.7-fold (0.89 log units) above; measured number outside the range, below it.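

In this assay the series now holds one readable change, a 2.5-fold lower number from compound 1 to compound 3 (0.39 log units; beyond the scatter), and it shows that with hydrogen in place of chloro on a saturated chain carbon bound to a carbonyl carbon, the number does not rise but falls beyond the usual scatter. The step from compound 2 to compound 3 cannot be read, as compound 2 has no number, so the change from allylsulfanyl to sulfanyl remains without a measured effect. Nothing available accounts for the shift at the chain carbon.

Going by these compounds, whether an amine or a longer chain on that carbon would raise or lower the number in this assay stays open. So does what a methyl group or a benzyl group on the sulfur would do there.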